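The compounds below may be only part of what the source reports. "The series", "measured", "known", "first", "only" and "open" are said of these compounds alone.

Of the compounds shown here, three have so far been tested in a functional assay on LCL cells (Homo sapiens) for cytotoxicity, read by MTT assay, with a stated time of 72 h; a lower number here means a stronger inhibitor, a higher number a weaker inhibitor. Compound 1 `CN1O[C@@H](n2ccc(N)nc2=O)C[C@@H]1c1ccccc1` reaches only a limit of the assay, > 100000 nM. Compound 2 `CN1O[C@@H](n2ccc(N)nc2=O)C[C@H]1c1ccccc1` likewise gives only a limit, > 100000 nM. The step that the two limits leave unreadable from compound 1 to compound 2 cannot be read, as the fact that compounds 1 and 2 differ only in the configuration as drawn makes clear. Within the data shown here, compound 3 `Cc1cn([C@@H]2C[C@H](c3ccccc3Cl)N(C)O2)c(=O)[nH]c1=O` is the one compound that gives an actual number in this assay, 52600 nM. The values of compound 1 and compound 2 both sit where the limit of > 100000 nM in this assay, at which 2 of the 3 values shown sit, describes.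

Compound 4 `Cc1cn([C@@H]2C[C@H](c3ccccc3)N(C)O2)c(=O)[nH]c1=O` differs from compound 3 in one place: hydrogen in place of chloro on an aromatic carbon. Among the measured compounds shown here, no measured step touches the chloro group or the phenyl ring, and the single measured step in this set, from compound 1 to compound 2, is unreadable. Nothing in these numbers therefore supports a shift in either direction beyond the scatter. Compound 4 is expected to give a value in this assay close to that of compound 3, with the step of a 1.5-fold higher number from compound 3 to compound 4 (0.18 log units; within the scatter) estimated to lie within the usual scatter, though a move up toward the limit of the assay remains possible. The estimate for compound 4 is 80000 nM, within a range from 25000 nM to 250000 nM.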

Compound 4, half-maximal inhibitory concentration: 82500 nM
Compound 4: the middle estimate sits 1.0-fold (0.01 log units) below what was measured; low and high end bracket the measured number.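

Among these compounds, this is the first readable step in the set, and it falls on the aromatic ring: in this assay, hydrogen in place of chloro on an aromatic carbon, ortho to a large group, gives a 1.6-fold higher number from compound 3 to compound 4 (0.20 log units; within the scatter). The change from 2-chlorophenyl to phenyl therefore leaves the two compounds indistinguishable in this assay, and compound 4, without the chlorine, still gives an actual number and not a limit. Nothing measured here accounts for the size of this step.

As far as these compounds go, whether a methoxy group, an amine or a carboxylic acid on this same carbon would shift the number beyond the scatter remains open, as does the outcome of placing chloro on another carbon of the ring. From the compounds shown here alone, it is also open whether the phenyl ring itself contributes to the reading, which a methyl group or a longer alkyl chain in its place could show, and whether a stereocentre change in this pair would produce a readable step.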